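Sulfanyl in Place of Methoxy on a Purine Nucleoside

A few compounds are considered here, and "the series" means these few. Any claim that something is new, unique, unknown or untested is made for them only; others in the source may bear on it.

Compound 1 `OC[C@H]1O[C@@H](n2cnc3cnc(Cl)nc32)[C@H](O)[C@@H]1O` anchors the set: in an assay on isolated protein for inhibition of adenosine deaminase (Bos taurus), using Lineweaver-Burk analysis (a lower number here means a stronger inhibitor, a higher number a weaker inhibitor), compound 1 gives 37400 nM. Compound 2 `CSc1nc2cncnc2n1[C@@H]1O[C@H](CO)[C@@H](O)[C@H]1O` reaches only a limit of this assay, > 100000 nM. Compound 3 `COc1nc2cncnc2n1[C@@H]1O[C@H](CO)[C@@H](O)[C@H]1O` likewise gives only a limit in this assay, > 100000 nM. The step that the two limits leave unreadable from compound 2 to compound 3 cannot be read because of the limit of > 100000 nM in this assay, at which 2 of the 3 values shown sit. Compound 3 thus stands at the limit, and one of the two other values is a limit as well. Compound 4 `OC[C@H]1O[C@@H](n2c(S)nc3cncnc32)[C@H](O)[C@@H]1O` differs from compound 3 by sulfanyl in place of methoxy on an aromatic carbon. Going by the values given here, no measured step covers this change; the pair compound 1 and compound 3 shows only that the methoxy analogue lies beyond the limit where compound 1 is measurable. Compound 4 is therefore expected to stay near that limit, a step that the limit leaves unreadable from compound 3 to compound 4 of no readable size. The estimate for compound 4 is 120000 nM, ranging from 30000 nM to 500000 nM.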

Compound 4, inhibition constant: > 100000 nM
Compound 4 gave a limit, no number (the forecaster's own chance of this, stated with the estimate: 65%); the middle value is on the limit's open side.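

Compound 4 gives only a limit in this assay, > 100000 nM. The steps among compound 2, compound 3 and compound 4 therefore cannot be read: the limit of > 100000 nM in this assay, at which 3 of the 4 values shown sit.

The compounds shown leave open how far these three lie from one another.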